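Methyl in place of fluoro: one change from compound 2

The source may report more compounds than this note shows. Statements on the series, on what has been measured and on what is new or still open speak of the compounds shown alone.

Measured so far in a functional assay on HeLa cells (Homo sapiens) for antiproliferative activity, read by sulforhodamine B assay, with a stated time of 72 h; a higher number here means a weaker inhibitor, a lower number a stronger inhibitor:
compound 1 `CN(C)C(=S)N/N=C/c1cc2cccnc2s1`: 48400 nM
compound 2 `Fc1ccccc1NC(=S)N/N=C/c1ccc2ccccc2n1`: > 100000 nM, a limit of the assay, not a number
compound 3 `NC(=S)N/N=C/c1cnc2ccccc2n1`: > 100000 nM, a limit of the assay, not a number

Compound 2 stands at the limit of this assay, as does compound 3 (the limit of > 100000 nM in this assay, at which 2 of the 3 values shown sit); only compound 1 gives a number. Compound 4 `Cc1ccccc1NC(=S)N/N=C/c1ccc2ccccc2n1` differs from compound 2 in one place: methyl in place of fluoro on an aromatic carbon. Going by the values given here, no measured pair carries this change, so its size in this assay is unknown from the series; the step from compound 2 to compound 4 is expected to be small, a step that the limit leaves unreadable from compound 2 to compound 4, with no firm direction and most likely not beyond the scatter. Compound 4 is therefore expected to remain near the limit, estimated at 150000 nM, within 40000 nM to 500000 nM.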

Compound 4, half-maximal inhibitory concentration: > 100000 nM
Compound 4 gave a limit, no number; the forecaster's own chance of this, stated with the estimate: 70%; the middle value does not contradict the limit.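

Compound 4, like compound 2, gives a limit and not a number, so no step can be read between them: the limit of > 100000 nM in this assay, at which 3 of the 4 values shown sit.

The compounds shown leave open whether methyl in place of fluoro on an aromatic carbon changes activity at all.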